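This account rests on a few compounds, and the source may have more. Where it says the series, first, only, none or still open, it means among the compounds named here.

Measured so far in an ADME assay on Huh-7 cells (Homo sapiens) for cytotoxicity; a higher number here means that more compound is tolerated, a lower number that less compound is tolerated:
compound 1 `O=C(c1nc2sccn2c1Cl)N1CCN(C2CCCC2)C(=O)C1` — > 10000 nM
compound 2 `CC(C)c1cn2c(Cl)c(C(=O)N3CCN(C4CCCC4)C(=O)C3)nc2s1` — > 10000 nM

Compound 1 stands at a limit of this assay rather than at a number: in this assay compound 1 gives > 10000 nM, the point at which the measurement stopped. Compound 2 is in the same position, and in this assay compound 2 also gives only the limit > 10000 nM. Within the data shown here, the single measured step, a step that the two limits leave unreadable from compound 1 to compound 2, therefore carries neither a size nor a direction, because both values sit at the limit of > 10000 nM in this assay, at which 2 of the 2 values shown sit.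

Compound 3 `CC(C)Cc1csc2nc(C(=O)N3CCN(C4CCCC4)C(=O)C3)c(Cl)n12` differs from compound 1 by isobutyl in place of hydrogen on an aromatic carbon. Among the measured compounds shown here, the only measured step that bears on this change is a step that the two limits leave unreadable from compound 1 to compound 2, and it is unreadable, so the measured data give no size to expect and no direction beyond the scatter. The account therefore rests on the two limits alone. For compound 3 the estimate in this assay is 15000 nM, with a range from 6000 nM to 40000 nM, and a further limit is expected as the most likely outcome. The step that the limit leaves unreadable from compound 1 to compound 3 is accordingly expected to be none beyond the scatter.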

Compound 3, half-maximal cytotoxic concentration: > 10000 nM
Compound 3 gave a limit, no number; the forecaster's own chance of this, stated with the estimate: 70%; the middle value does not contradict the limit.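

In this assay compound 3 gives > 10000 nM as a limit and not a number. No step between compound 1 and compound 3 can therefore be read, as all the compounds shown stand at one value: the limit of > 10000 nM in this assay, at which 3 of the 3 values shown sit. The compounds shown leave open whether isopropyl or isobutyl in place of hydrogen changes how much compound is tolerated.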